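The compounds below may be only part of what the source reports. "The series", "measured", "known", "first", "only" and "open" are said of these compounds alone.

Measured so far in an assay on isolated protein for inhibition of phosphodiesterase 4A (Sus scrofa); a higher number here means a weaker inhibitor, a lower number a stronger inhibitor: compound 1, `COc1ccc(C(=O)Nc2c(C)cccc2Cl)cc1OC1CCCC1`, 100 nM; compound 2, `COc1ccc(C(=O)Nc2ccccc2Cl)cc1OC(C)=O`, 70000 nM.

Compound 1 stands at the lowest of the two numbers, and the gap to compound 2 is well beyond the scatter. Among the measured compounds shown here, the two measured compounds differ in more than one place, so no single-change step is known in this assay.

Compound 3, `COc1ccc(C(=O)NN2C(Cl)=NC=CC2Cl)cc1OC1CCCC1`, is to be measured. It differs from compound 1 as follows: a group of 8 heavy atoms (4 carbon, 2 nitrogen, 2 chlorine; one six-membered non-aromatic ring with 2 hetero atoms) in place of a group of 8 heavy atoms (7 carbon, 1 chlorine; one six-membered aromatic ring of carbon only), on an amide-type nitrogen. A change of this size, on the amide-type nitrogen of the shared core, is expected to weaken inhibition in this assay, by a step of a 30-fold higher number from compound 1 to compound 3 (1.48 log units; beyond the scatter). Compound 3 is estimated at 3000 nM, within 300 nM to 30000 nM.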

Compound 3, half-maximal inhibitory concentration: 400 nM
For compound 3 the middle estimate is 7.5-fold (0.88 log units) above the measured one; the measured number falls inside the stated range.
By their numbers in this assay, from the lowest: compound 1; then compound 3; then compound 2.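

In this assay, replacing the 2-chloro-6-methylphenyl group on the amide-type nitrogen with a non-aromatic ring holding 2 hetero atoms is a modest step, a 4.0-fold higher number from compound 1 to compound 3 (0.60 log units; beyond the scatter). At this position, then, a six-membered aromatic ring of carbon only is not needed for inhibition of this order. No measurement on hand accounts for the size of this step.

On these data alone, how a pyridine ring or an unsubstituted phenyl on this nitrogen would compare remains open. Also open, as far as these compounds go, is what each chlorine of the entering group contributes, which a version carrying hydrogen or methyl in its place would test.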